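A few compounds are considered here, and "the series" means these few. Any claim that something is new, unique, unknown or untested is made for them only; others in the source may bear on it.

Measured so far:
compound 1 `CN(C)CCn1cnnc1-c1cc(Oc2ccc(NC(=O)N/N=C/c3c(Cl)cccc3Cl)cc2F)ccn1` — 350 nM
compound 2 `CN(C)CCn1cnnc1-c1cc(Oc2ccc(NC(=O)N/N=C/c3ccc(F)cc3)cc2F)ccn1` — 1980 nM

For the measured compounds named here, in a functional assay on NCI-H460 cells (Homo sapiens) for cytotoxicity, read by MTT assay, with a stated time of 72 h (a higher number here means a weaker inhibitor, a lower number a stronger inhibitor), compound 2 gives the higher of the two numbers, and the only step that joins the two measured compounds, a 5.7-fold higher number from compound 1 to compound 2 (0.75 log units; beyond the scatter), shows that exchanging the aromatic group on the carbon carrying the double bond to nitrogen can move the number well beyond the usual scatter. Compound 3 `CN(C)CCn1cnnc1-c1cc(Oc2ccc(NC(=O)N/N=C/c3c(O)ccc4ccccc34)cc2F)ccn1` keeps everything else and differs from compound 2 only in that same spot: 2-hydroxynaphthalen-1-yl in place of 4-fluorophenyl on a carbon with a double bond to nitrogen. Going by the values given here, the step from compound 1 to compound 2 is the sole guide here; it shows that a ring other than 4-fluorophenyl at this position gave a clearly lower number, but it says nothing about a naphthalene ring bearing a hydroxyl group, so the direction of the new change cannot be pinned down from the data. Because the measured step of a 5.7-fold higher number from compound 1 to compound 2 (0.75 log units; beyond the scatter) shows this position to be sensitive, a step of modest size is expected, most plausibly toward a lower number as with compound 1, with a wide range allowed. Compound 3 is therefore expected to give about 800 nM in this assay, within 200 nM to 3000 nM, meaning an estimated step of a 2.5-fold lower number from compound 2 to compound 3 (0.39 log units; beyond the scatter).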

Compound 3, half-maximal inhibitory concentration: 890 nM
Compound 3: middle estimate off by 1.1-fold (0.05 log units), on the low side, within the range that was stated.
By their numbers in this assay, from the lowest: compound 1; then compound 3; then compound 2.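

In this assay, the step to a group with two six-membered aromatic rings and a hydroxyl group is a 2.2-fold lower number from compound 2 to compound 3 (0.35 log units; beyond the scatter), so this position accepts a group of 11 heavy atoms, larger than 4-fluorophenyl, and the number still falls. That group does not match 2,6-dichlorophenyl, however, with a 2.5-fold higher number from compound 1 to compound 3 (0.41 log units; beyond the scatter), and so the two-ring group lands in the middle of the two single-ring groups, which shows that the ring count alone does not set the order among these three compounds. No accompanying measurement accounts for these differences.

The 2-hydroxynaphthalen-1-yl group brings the second ring and the hydroxyl group in a single change, so the compounds shown cannot say how much of the step from 4-fluorophenyl belongs to each; a plain naphthalen-1-yl or a 2-hydroxyphenyl group on the same carbon would separate the two. Also open, as far as these compounds go, is how the number responds at this position to groups of a different kind, such as a ring carrying an amine or a carboxylic acid, or a saturated ring such as cyclohexyl.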